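Naphthalen-2-yl in place of phenyl: notes on compound 4

The compounds below may be only part of what the source reports. "The series", "measured", "known", "first", "only" and "open" are said of these compounds alone.

Compound 1 `O=c1c(-c2cccc([N+](=O)[O-])c2)nc2ccccc2n1Cc1ccccc1` is the reference point of the series. Going by the values given here, in an assay on cells for activation of Cystic fibrosis transmembrane conductance regulator (Homo sapiens), read by fluorescence, with a stated time of 10 min (a lower number here means that less compound is needed, a higher number that more compound is needed for the effect), compound 1 gives 9 nM, the lowest of the three numbers measured so far. Compound 2 `O=c1c(-c2ccccc2)nc2ccccc2n1Cc1ccccc1` gives 5000 nM in this assay, and the step of a 560-fold higher number from compound 1 to compound 2 (2.74 log units; beyond the scatter) is large. Compound 3 `N#Cc1cccc(-c2nc3ccccc3n(Cc3ccccc3)c2=O)c1` gives 1000 nM in this assay; the step of a 110-fold higher number from compound 1 to compound 3 (2.05 log units; beyond the scatter) is also large, while a 5.0-fold lower number from compound 2 to compound 3 (0.70 log units; beyond the scatter) is modest. All three measured steps concern the group on an aromatic carbon, and the nitro variant, compound 1, stands clearly apart from the other two.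

Compound 4 `O=c1c(-c2cccc([N+](=O)[O-])c2)nc2ccccc2n1Cc1ccc2ccccc2c1` differs from compound 1 elsewhere: naphthalen-2-yl in place of phenyl on a saturated chain carbon bound to an aromatic nitrogen. Among the compounds with values here, none of the measured steps touches this chain carbon, so there is no direct precedent for the change; the measured steps show only that the nitro group, which compound 4 keeps, goes with the lowest numbers. With the nitro group retained and no measured guide for the change at the chain carbon, compound 4 is expected to give in this assay a number close to that of compound 1, a step of a 1.1-fold higher number from compound 1 to compound 4 (0.05 log units; within the scatter) not beyond the scatter, with a wide range to reflect the lack of precedent. The estimate for compound 4 is 10 nM, between 3 nM and 40 nM.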

Compound 4, half-maximal effective concentration: 4300 nM
Estimate against measurement, compound 4: 430-fold (2.63 log units) below, outside the stated range (above it).
By their numbers in this assay, from the lowest: compound 1; then compound 3; then compounds 4 and 2 (each within the scatter of the next).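

In this assay, the change from one to two six-membered aromatic rings of carbon only, on a saturated chain carbon bound to an aromatic nitrogen, brings a 480-fold higher number from compound 1 to compound 4 (2.68 log units; beyond the scatter). Going by these compounds alone, this position therefore matters to the result as much as the group on the aromatic carbon did in the earlier compounds, and keeping the nitro group is not enough on its own to hold the number low. Nothing available explains the size of this step.

What the compounds shown leave open is how other groups behave at this chain carbon, such as methyl, a pyridinyl ring or naphthalen-1-yl, so a single step cannot separate the effect of the added ring from that of its attachment. Also open, on these data alone, is whether naphthalen-2-yl has a similar effect when hydrogen or cyano replaces the nitro group.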